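Compound 3 to compound 4: a longer bromine-bearing group

This account rests on a few compounds, and the source may have more. Where it says the series, first, only, none or still open, it means among the compounds named here.

Measured in a functional assay on HCT-116 cells (Homo sapiens) for inhibition, read by MTT assay, with a stated time of 48 h; on this read-out lower numbers stand for stronger inhibition and higher numbers for weaker inhibition:
- compound 1 `COc1ccc(CN(C(=O)C(C)Br)c2cc(OC)c(OC)c(OC)c2)cc1O` gives 140 nM
- compound 2 `COc1ccc(CN(C(=O)C=C(C)C)c2cc(OC)c(OC)c(OC)c2)cc1O` gives 290 nM
- compound 3 `COc1ccc(CN(C(=O)CCl)c2cc(OC)c(OC)c(OC)c2)cc1O` gives 250 nM

Compound 3 stands within the scatter of both other compounds, as the two steps that reach it show: a 1.8-fold higher number from compound 1 to compound 3 (0.25 log units; within the scatter) and a 1.2-fold lower number from compound 2 to compound 3 (0.06 log units; within the scatter). Within the data shown here, only one step in the set exceeds the scatter, and it is modest: a 2.1-fold higher number from compound 1 to compound 2 (0.32 log units; beyond the scatter).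

The unmeasured compound 4 `COc1ccc(CN(C(=O)/C=C/CBr)c2cc(OC)c(OC)c(OC)c2)cc1O` carries 3-bromoprop-1-en-1-yl in place of chloromethyl on a carbonyl carbon. All three measured steps bear on this change, since each swaps the group at that same carbonyl carbon. Among the measured compounds shown here, the entering group shares bromine with the 1-bromoethyl of compound 1 and a double bond with the 2-methylprop-1-en-1-yl of compound 2, yet it matches neither group, and no measured compound combines the two features. The three measured values span only a narrow window, so a small move towards a lower number is the most that is expected. The estimated step is a 1.4-fold lower number from compound 3 to compound 4 (0.14 log units; within the scatter), and no step beyond the scatter is expected. For compound 4 the estimated value is 180 nM, with an expected range from 60 nM to 500 nM.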

Compound 4, half-maximal inhibitory concentration: 59 nM
Beside the measured number, compound 4's estimate is 3.1-fold (0.48 log units) above it, and the stated range ends above it.
By their numbers in this assay, from the lowest: compound 4; then compounds 1, 3 and 2 (each within the scatter of the next, the first and the last beyond it).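

In this assay, among these compounds, the step from the chloromethyl group to 3-bromoprop-1-en-1-yl on the carbonyl carbon is the largest of its kind so far at this position, a 4.2-fold lower number from compound 3 to compound 4 (0.63 log units; beyond the scatter), and it shows that this place can move the number well beyond the narrow window of the earlier compounds. Compound 4 also stands clear of the other two, with a 4.9-fold lower number from compound 2 to compound 4 (0.69 log units; beyond the scatter) and a 2.4-fold lower number from compound 1 to compound 4 (0.38 log units; beyond the scatter), so it is the most potent of the four, and neither bromine without a double bond, as in the 1-bromoethyl of compound 1, nor a double bond without bromine, as in the 2-methylprop-1-en-1-yl of compound 2, gives a number this low. Nothing in the data shown accounts for this gain.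

As far as these compounds go, it remains open whether the step needs both features together, a question that a saturated 3-bromopropyl chain and a 3-chloroprop-1-en-1-yl group would each address. Also open, from the compounds shown here alone, is how a terminal amine or a carboxylic acid in place of the bromine would read on the same core, and whether the order of the four compounds holds in other cell lines.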